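The source may report more compounds than this note shows. Statements on the series, on what has been measured and on what is new or still open speak of the compounds shown alone.

Measured so far: compound 1, `CC[C@H](C)[C@H](N)CN(C(=O)[C@@H]1C[C@H]1c1ccccc1)c1ccc(-c2ccccc2)cc1`, with 230 nM; 800 nM (2 entries) in a functional assay for agonist activity at G protein-coupled receptor 88 (Homo sapiens), read by HTRF and cAMP accumulation; on this read-out higher numbers stand for an effect only at larger amounts of compound and lower numbers for an effect already at smaller amounts; compound 2, `CC[C@H](C)[C@H](N)CN(C(=O)[C@@H]1C[C@H]1c1ccc(Cl)cc1)c1ccc(-c2ccccc2)cc1`, with 4300 nM.

Within the data shown here, compound 2 stands at 4300 nM in this assay, its only number there, beside one further entry without a single number; compound 1 sits lower, as the several entries of compound 1 in this assay, 230 nM; 800 nM (2 entries) shows. Compound 3, `CC[C@H](C)[C@H](N)CN(C(=O)[C@@H]1C[C@H]1c1cccc(Cl)c1)c1ccc(-c2ccccc2)cc1`, differs from compound 2 by 3-chlorophenyl in place of 4-chlorophenyl on a saturated ring carbon. Among the measured compounds shown here, no measured step of this kind exists, so its size is uncertain; the change is expected to fall within the scatter, with no clear direction. Compound 3 is therefore estimated at 3500 nM, within 900 nM to 14000 nM. The expected step is a 1.2-fold lower number from compound 2 to compound 3 (0.09 log units; within the scatter).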

Compound 3, half-maximal effective concentration: 2200 nM
Estimate against measurement, compound 3: 1.6-fold (0.20 log units) above; the range from low to high includes it.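

Exchanging 4-chlorophenyl for 3-chlorophenyl on this saturated ring carbon gives, in this assay, a 2.0-fold lower number from compound 2 to compound 3 (0.29 log units; within the scatter), so the two chlorinated compounds cannot be told apart on this read-out. Compound 3, at 2200 nM, still stands above both entries of compound 1, so neither placing of the chlorine brings the number down to that of the unsubstituted phenyl. Repeats can themselves lie well apart here: the several entries of compound 1 in this assay, 230 nM; 800 nM (2 entries). As far as these compounds go, whether a fluorine, a methoxy group or a nitrile in place of the chlorine would read differently remains open.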